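This account rests on a few compounds, and the source may have more. Where it says the series, first, only, none or still open, it means among the compounds named here.

Working notes on the series in a functional assay on MDA-MB-231 cells (Homo sapiens) for cytotoxicity, read by MTT assay, with a stated time of 72 h; on this read-out higher numbers stand for weaker inhibition and lower numbers for stronger inhibition. Compound 1 `CC1(C)OCC(Cn2cc(Cn3c4c(c5ccccc53)C(=O)c3c[n+]([O-])c5ccccc5c3C4=O)nn2)O1` gives 230 nM. Compound 2 `O=C1c2c[n+]([O-])c3ccccc3c2C(=O)c2c1c1ccccc1n2CCN1CCCC1` gives 630 nM, the higher of the two numbers shown, with compound 1 the nearest of them. Compound 3 `CC1(C)OC[C@@H](Cn2cc(Cn3c4c(c5ccccc53)C(=O)c3c[n+]([O-])c5ccccc5c3C4=O)nn2)O1` returns a limit of the assay, > 1000 nM, and not a number. For the measured compounds named here, the one step between compounds differing in a single place is an at least 4.3-fold higher number from compound 1 to compound 3 (0.63 log units; beyond the scatter), whose full size stays open because of the limit of > 1000 nM in this assay, at which 1 of the 3 values shown sits; the two compounds part only in that (the fact that one of compounds 1 and 3 is drawn with a defined configuration and the other without, at the place where they differ).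

Compound 4 `O=C1c2c[n+]([O-])c3ccccc3c2C(=O)c2c1c1ccccc1n2CCN1CCCCC1` is not yet measured. It differs from compound 2 by piperidin-1-yl in place of pyrrolidin-1-yl on a saturated chain carbon, two bonds along the chain from an aromatic nitrogen. Going by the values given here, no measured step bears on this kind of change: the single recorded step turns on a stereocentre drawn with or without configuration, not on the pyrrolidin-1-yl or piperidin-1-yl group, and compound 1 and compound 3 carry a different substituent on the aromatic nitrogen altogether. With nothing in the set pointing either way, no step beyond the scatter is expected in this assay, so the estimate for compound 4 is 630 nM, with a range from 250 nM to 1600 nM, which means an expected step of no change at the digits printed from compound 2 to compound 4 (within the scatter).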

Compound 4, half-maximal inhibitory concentration: 1050 nM
The estimate for compound 4 lay 1.7-fold (0.22 log units) below the measured number; the measured number falls inside the stated range.
By their numbers in this assay, from the lowest: compound 1; then compounds 2 and 4 (each within the scatter of the next).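

In this assay, for the compounds shown here, this is the first readable step at this place, on a saturated chain carbon, two bonds along the chain from an aromatic nitrogen: with piperidin-1-yl in place of pyrrolidin-1-yl, the result is a 1.7-fold higher number from compound 2 to compound 4 (0.22 log units; within the scatter). Going by these compounds alone, the six-membered ring therefore does not separate from the five-membered ring in this assay, a point the earlier compounds could not address, since their only step turned on a stereocentre drawn with or without configuration in a different substituent on the aromatic nitrogen. Nothing measured in the series accounts for this result or assigns a property to either ring.

Going by these compounds, whether a more different group at the end of the same chain, such as morpholin-4-yl or an open-chain dimethylamino group, or a longer chain between the aromatic nitrogen and the pyrrolidin-1-yl group, would move the number beyond the scatter remains open. A single pair also leaves open whether piperidin-1-yl and pyrrolidin-1-yl would stay within the scatter of each other on a chain of another length or in another cell line.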